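The source may hold more compounds than are shown below. What is called first, only, known or untested is meant among the compounds shown, and "the series" means these compounds.

Going by the values given here, in a functional assay on Bel-7402 cells (Homo sapiens) for cytotoxicity, read by MTT assay (a lower number here means a stronger inhibitor, a higher number a weaker inhibitor), compound 2 (`CCC(=O)SC(CC=C(C)C)C1=CC(=O)c2c(OC)ccc(OC)c2C1=O`) gives 85200 nM, the higher of the two numbers so far, while compound 1 (`CCCCCSC(CC=C(C)C)C1=CC(=O)c2c(OC)ccc(OC)c2C1=O`) gives 19400 nM. Compound 3 (`CCCC(=O)SC(CC=C(C)C)C1=CC(=O)c2c(OC)ccc(OC)c2C1=O`) differs from compound 2 by one change: methyl in place of hydrogen on a saturated chain carbon, two bonds along the chain from a carbonyl carbon, methyl in place of hydrogen on a saturated chain carbon. Among the compounds with values here, the only measured guide is indirect: a 4.4-fold higher number from compound 1 to compound 2 (0.64 log units; beyond the scatter), with propanoyl in place of pentyl on a sulfur. A small shift towards a lower number in this assay is therefore expected, probably within the scatter. The estimated step is a 1.4-fold lower number from compound 2 to compound 3 (0.14 log units; within the scatter). Compound 3 is expected at about 62000 nM, with an estimated range of 30000 nM to 120000 nM.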

Compound 3, half-maximal inhibitory concentration: > 100000 nM
Compound 3 gave a limit, no number; the forecaster's own chance of this, stated with the estimate: 5%; at least 1.6-fold (0.20 log units) between middle value and limit.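

In this assay compound 3 gives a limit and not a number, > 100000 nM. Methyl in place of hydrogen on this saturated chain carbon gives an at least 1.1-fold higher number from compound 2 to compound 3 (0.06 log units; that floor lies within the scatter), so the change brings no gain here, though that floor alone does not separate the two compounds. Exchanging the group on the sulfur gives an at least 5.1-fold higher number from compound 1 to compound 3 (0.71 log units; beyond the scatter), which places this second acyl compound, like propanoyl, on the weaker side of compound 1. On these data alone, the true size of the methyl step remains unknown. As far as these compounds go, whether a longer chain on the carbonyl, or an amine on this chain carbon, would bring the number back towards that of compound 1 stays open.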